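This account rests on a few compounds, and the source may have more. Where it says the series, first, only, none or still open, it means among the compounds named here.

Of the compounds shown here, three have been measured so far in a functional assay on HepG2 cells (Homo sapiens) for inhibition, read by MTT assay, with a stated time of 48 h; a lower number here means a stronger inhibitor of growth, a higher number a weaker inhibitor of growth. Compound 1, `Cn1cc(C2CC(c3ccccc3)=NN2C(=O)c2cccnc2)c2cc(Br)ccc21`, gives 2520 nM. Compound 2, `COc1ccc2c(c1)c(C1CC(c3ccccc3)=NN1C(=O)c1cccnc1)cn2C`, gives 5110 nM in this assay. The two differ in one place, (methoxy in place of bromo on an aromatic carbon), and this change gave a 2.0-fold higher number from compound 1 to compound 2 (0.31 log units; beyond the scatter). Compound 3, `COc1ccc2c(c1)c(C1CC(c3ccc(Br)cc3)=NN1C(=O)c1ccc(OC)nc1)cn2C`, is described by a limit of this assay rather than by a number, > 10000 nM. The difference between the core of compound 1 and the core of compound 3 is not broken down here.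

Compound 4, `COc1ccc(C2=NN(C(=O)c3ccc(OC)nc3)C(c3cn(C)c4ccc(OC)cc34)C2)cc1`, has not yet been measured. It differs from compound 3 in one place, (methoxy in place of bromo on an aromatic carbon). Within the data shown here, this is the same kind of change as the one from compound 1 to compound 2, but its surroundings differ: in compound 4 the methoxy sits on a six-membered aromatic ring of carbon only, para to a large group, whereas in compound 2 it sits on a ring that is part of a fused or bridged system of two rings, meta to a fused ring and para to a fused ring.

For compound 4 a step that the limit leaves unreadable from compound 3 to compound 4 is expected, since the same change gave a 2.0-fold higher number from compound 1 to compound 2 (0.31 log units; beyond the scatter), and compound 3 already stands at the limit of > 10000 nM in this assay, at which 1 of the 3 values shown sits. Compound 4 is therefore estimated to give 20000 nM in this assay, most likely reported only as a limit, with a range from 8000 nM to 60000 nM.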

Compound 4, concentration for 50% growth inhibition: 230 nM
Estimate against measurement, compound 4: 87-fold (1.94 log units) above, and the stated range ends above it.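

In this assay, the change to 4-methoxyphenyl gave an at least 43-fold lower number from compound 3 to compound 4 (1.63 log units; beyond the scatter), so on this core methoxy in place of bromo went with a much stronger inhibitor of growth. On these data alone, compound 3 gives > 10000 nM, which is a limit of the assay and not a number, so the full size of this step stays unknown. The change therefore does not carry over from one core to the other in either size or direction, although these two pairs cannot show which difference between the cores, or the different place of the change, accounts for this: the same change on two cores in this assay, a 2.0-fold higher number (0.31 log units; beyond the scatter) from compound 1 to compound 2 and an at least 43-fold lower number (1.63 log units; beyond the scatter) from compound 3 to compound 4, at least 88-fold (1.94 log units) apart, beyond the scatter of two such steps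

The compounds shown leave open whether a methoxy group is specifically needed on the phenyl ring of compound 4, or whether a hydroxyl, an amine or a longer chain such as ethoxy would give a similar number. They also leave open whether the large step would hold with bromo rather than methoxy on the fused ring system, a pairing that would show whether the two places depend on each other.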